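This account rests on a few compounds, and the source may have more. Where it says the series, first, only, none or still open, it means among the compounds named here.

Measured so far in a functional assay on T-24 cells (Homo sapiens) for cytotoxicity, read by CCK-8 assay, with a stated time of 24 h; on this read-out lower numbers stand for stronger inhibition and higher numbers for weaker inhibition:

compound 1 `C/C(=C\c1ccc(-c2ccc(C)cc2)o1)C(N)=O` gives > 50000 nM, a limit of the assay
compound 2 `C/C(=C\c1ccc(-c2ccc(F)cc2)o1)C(N)=O` gives 3320 nM
compound 3 `C/C(=C\c1cc(-c2ccc(C)cc2)cs1)C(N)=O` gives > 50000 nM, a limit of the assay

Compound 1 and compound 2 share one core and differ by fluoro in place of methyl on an aromatic carbon. This change brings an at least 15-fold lower number from compound 1 to compound 2 (1.17 log units; beyond the scatter). The starting point of that step is a limit and not a number, so the true size of the step is open; it is only known to be at least as large as shown, a point that rests on (the limit of > 50000 nM in this assay, at which 2 of the 3 values shown sit).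

Compound 3 carries a different core; the difference between the core of compound 1 and the core of compound 3 is not broken down here. Compound 4 `C/C(=C\c1cc(-c2ccc(F)cc2)cs1)C(N)=O` is the partner of compound 3 on this second core and has not yet been measured in this assay. Among the compounds with values here, it differs from compound 3 by fluoro in place of methyl on an aromatic carbon, the same change as the one made from compound 1 to compound 2, with the same surroundings around the place.

Since compound 3 also sits at the limit, the expectation for compound 4 can only borrow from the step seen on the first core, with the caution that the cores differ and that a single example carries little weight. The step from compound 3 to compound 4 is estimated as an at least 6.2-fold lower number from compound 3 to compound 4 (0.79 log units; beyond the scatter), held somewhat smaller than the measured one to allow for the unknown core effect. Compound 4 is therefore estimated at 8000 nM, with a range from 2000 nM to 50000 nM, and a fair chance remains that the assay again reports only a limit.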

Compound 4, half-maximal inhibitory concentration: > 50000 nM
Compound 4: no number, only a limit (the forecaster's own chance of this, stated with the estimate: 30%); middle value at least 6.2-fold (0.79 log units) away from the limit.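

In this assay compound 4 gives > 50000 nM, a limit of the assay. Compound 3 also stands at a limit, so no step can be read between compound 3 and compound 4: the limit of > 50000 nM in this assay, at which 3 of the 4 values shown sit.

The compounds shown leave open whether fluoro in place of methyl changes the number at all on the core of compound 3, as it does on the core of compound 1.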